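A few compounds are considered here, and "the series" means these few. Any claim that something is new, unique, unknown or untested is made for them only; others in the source may bear on it.

Compound 2 `CCC(CC)c1ccc2c(NCCCNCc3ccco3)ccnc2c1` is the anchor of this small set. In an ADME assay on HepG2 cells (Homo sapiens) for cytotoxicity, read by luminescence, CellTiter-Glo and ATP content, with a stated time of 72 h (a lower number here means that less compound is needed, a higher number that more compound is needed for the effect), compound 2 gives 6760 nM. Compound 1 `CCC(CC)c1ccc2c(NCCCNCc3cc(F)ccc3OC)ccnc2c1` differs from it by 5-fluoro-2-methoxyphenyl in place of furan-2-yl on a saturated chain carbon bound to an amine nitrogen; in this assay compound 1 gives 7860 nM, so that change made a 1.2-fold higher number from compound 2 to compound 1 (0.07 log units; within the scatter). Compound 3 `COc1ccc(-c2ccc3c(NCCCNCc4ccco4)ccnc3c2)cc1` carries a different core, the two cores differing by 4-methoxyphenyl in place of pentan-3-yl on an aromatic carbon; in this assay compound 3 gives 6000 nM, which is a 1.1-fold lower number from compound 2 to compound 3 (0.05 log units; within the scatter). Compound 4 `COc1ccc(-c2ccc3c(NCCCNCc4cc(F)ccc4OC)ccnc3c2)cc1` has not yet been measured in this assay. It differs from compound 3 by 5-fluoro-2-methoxyphenyl in place of furan-2-yl on a saturated chain carbon bound to an amine nitrogen, the same change, at the same place, that separates compound 1 from compound 2. Because the earlier step was a 1.2-fold higher number from compound 2 to compound 1 (0.07 log units; within the scatter), a step of similar size, a 1.2-fold higher number from compound 3 to compound 4 (0.07 log units; within the scatter), is expected for compound 4. Compound 4 is therefore expected to give about 7000 nM in this assay.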

Compound 4, half-maximal effective concentration: 5960 nM
Beside the measured number, compound 4's estimate is 1.2-fold (0.07 log units) above it; the range from low to high includes it.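

In this assay, 5-fluoro-2-methoxyphenyl in place of furan-2-yl on the core carrying 4-methoxyphenyl gave a 1.0-fold lower number from compound 3 to compound 4 (0.00 log units; within the scatter), and the two steps for this change agree: the same change on two cores in this assay, a 1.2-fold higher number (0.07 log units; within the scatter) from compound 2 to compound 1 and a 1.0-fold lower number (0.00 log units; within the scatter) from compound 3 to compound 4, 1.2-fold (0.07 log units) apart, within the scatter of two such steps. With 4-methoxyphenyl in place of pentan-3-yl, the step was a 1.3-fold lower number from compound 1 to compound 4 (0.12 log units; within the scatter), and this change also agrees across the two cores: the same change on two cores in this assay, a 1.1-fold lower number (0.05 log units; within the scatter) from compound 2 to compound 3 and a 1.3-fold lower number (0.12 log units; within the scatter) from compound 1 to compound 4, 1.2-fold (0.07 log units) apart, within the scatter of two such steps. Within the data shown here, since every one of these steps lies within the scatter, the agreement shows only that neither change measurably moved this number on either core, not that a change with a measurable effect would carry from one core to another. Open, on these data alone, is whether a longer chain, or an amide in place of the amine, would move the number. So is whether a carboxylic acid on the aromatic carbon would do so.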